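Ethyl for methyl on the core of compound 1

The compounds below may be only part of what the source reports. "The series", "measured", "known", "first", "only" and "open" are said of these compounds alone.

compound 1 `Cc1c(Nc2ccc(S(C)(=O)=O)cc2F)ncnc1O[C@H]1CC[C@]2(CC1)COC(C)(C)C2` — 13 nM
compound 2 `Cc1c(O[C@H]2CC[C@]3(CC2)COC(C)(C)C3)ncnc1N(C)c1ccc(S(C)(=O)=O)cc1F` — > 1000 nM

In a functional assay on HEK293 cells for agonist activity at Glucose-dependent insulinotropic receptor (Homo sapiens), read by HTRF and cAMP accumulation, with a stated time of 30 min (on this read-out higher numbers stand for an effect only at larger amounts of compound and lower numbers for an effect already at smaller amounts), compound 1 gives 13 nM, the only number shown in this assay. Compound 2 yields only a limit in this assay, > 1000 nM. Among the compounds with values here, the single measured step, an at least 76-fold higher number from compound 1 to compound 2 (1.88 log units; beyond the scatter), comes from putting a methyl in place of a hydrogen on a nitrogen on an aromatic ring, and it is large. Compound 3 `CCc1c(Nc2ccc(S(C)(=O)=O)cc2F)ncnc1O[C@H]1CC[C@]2(CC1)COC(C)(C)C2` alters a different place on the shared core: methyl in place of hydrogen on a saturated chain carbon bound to an aromatic carbon. Within the data shown here, no measured step touches that saturated chain carbon bound to an aromatic carbon, so the large loss seen with compound 2 gives no guidance either way for compound 3, and the data hold nothing that speaks for a gain or a loss from this change. In the absence of any comparable step, the expected outcome is a change no larger than the usual scatter, a 1.2-fold higher number from compound 1 to compound 3 (0.06 log units; within the scatter). Compound 3 is therefore estimated at about 15 nM in this assay, with a range from 4 nM to 60 nM, and the measured value will show whether that expectation holds.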

Compound 3, half-maximal effective concentration: 42 nM
Estimate against measurement, compound 3: 2.8-fold (0.45 log units) below; the range from low to high includes it.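

In this assay, within the data shown here, going from methyl to ethyl on the shared core gives a 3.2-fold higher number from compound 1 to compound 3 (0.51 log units; beyond the scatter) and so shows for the first time that this position responds to a change. The response is modest, and the extra carbon is tolerated in part: compound 3 still gives 42 nM as a full number and keeps an effect at small amounts of compound. The data show only the size of this step, and nothing measured here explains why one added carbon on a saturated chain carbon bound to an aromatic carbon raises the number.

A single step cannot show whether the number keeps rising as the group grows, so a longer chain such as propyl, or a branched group such as isopropyl, could lose more or could lose no more than ethyl does. The compounds shown also leave open what a small ring such as cyclopropyl, a chlorine atom or a plain hydrogen in this same place would give, and so whether the methyl of compound 1 is the best choice here.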